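Three Aromatic Substituents, One Efficacy: a Furan Follows

A few compounds are considered here, and "the series" means these few. Any claim that something is new, unique, unknown or untested is made for them only; others in the source may bear on it.

Measured compounds:
compound 1 `N#Cc1cc(-c2nc(C(c3ccc(F)cc3)c3ccc(F)cc3)sc2CC(=O)O)ccc1F`: 80%
compound 2 `O=C(O)Cc1sc(C(c2ccc(F)cc2)c2ccc(F)cc2)nc1-c1cc(F)cc(F)c1`: 80%
compound 3 `O=C(O)Cc1sc(C(c2ccc(F)cc2)c2ccc(F)cc2)nc1-c1ccnc(N2CCC2)c1`: 80%

In an in vitro functional assay on HEK285-7 cells for antagonist activity at prostaglandin D2 receptor 2 (Homo sapiens), read by BRET and beta-arrestin recruitment (a lower number here means a smaller maximal response, a higher number a larger maximal response), compound 3 stands level with compounds 1 and 2 at the digits shown; its nearest neighbour is compound 1 and its furthest is compound 2, and neither gap exceeds the scatter. The three measured steps are all flat: no change at the digits printed from compound 1 to compound 2 (within the scatter), no change at the digits printed from compound 1 to compound 3 (within the scatter) and no change at the digits printed from compound 2 to compound 3 (within the scatter). Each of them swaps the aromatic group attached to the shared core while the rest of the molecule stays fixed, and none of them moved the maximal response.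

Compound 4 `O=C(O)Cc1sc(C(c2ccc(F)cc2)c2ccc(F)cc2)nc1-c1ccco1` is the next member of the series and has not yet been measured. The change from compound 3 is furan-2-yl in place of 2-(azetidin-1-yl)pyridin-4-yl on an aromatic carbon. This is again an exchange of the aromatic group at the same position of the shared core, the same kind of change that gave the three flat steps above. Those steps are the ones that bear on it, and they were all within the scatter, so the expected step in this assay is none beyond the scatter: no change at the digits printed from compound 3 to compound 4 (within the scatter) is the expected change from compound 3 to compound 4.

Compound 4 is therefore expected to give about 80% in this assay, within an estimated range of 65% to 95%.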

Compound 4, largest response reached (reported as efficacy), in percent of the reference or control that the assay uses: 80%
Compound 4: middle estimate and measured number agree at the digits printed; low and high end bracket the measured number.
By their numbers in this assay, from the lowest: compounds 1, 2, 3 and 4 (each within the scatter of the next).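

In this assay, the earlier compounds all carried a six-membered aromatic ring on this aromatic carbon of the shared core, and compound 4 is the first shown with a five-membered aromatic ring there: furan-2-yl, with 5 heavy atoms and 1 hydrogen-bond acceptor, replaces 2-(azetidin-1-yl)pyridin-4-yl, with 10 heavy atoms and 2 hydrogen-bond acceptors, and the result is no change at the digits printed from compound 3 to compound 4 (within the scatter). The two other comparisons agree, with no change at the digits printed from compound 2 to compound 4 (within the scatter) when furan-2-yl replaces 3,5-difluorophenyl and no change at the digits printed from compound 1 to compound 4 (within the scatter) when it replaces 3-cyano-4-fluorophenyl, so this position tolerates a smaller heavy-atom count of the group and an oxygen-containing ring without a shift in the maximal response in this assay. The data shown offer no explanation for this flatness.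

All four compounds have an aromatic ring at this place, which leaves open whether a saturated ring such as piperidine, a small alkyl group such as methyl or a simple amine would give the same response. As far as these compounds go, the carboxymethyl group is also common to all four, so the effect of a longer acid chain in its place remains open.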